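Removing the acetyl from compound 1

The source may hold more compounds than are shown below. What is called first, only, known or untested is meant among the compounds shown, and "the series" means these compounds.

In a functional assay on A-375 cells (Homo sapiens) for antiproliferative activity, read by trypan blue exclusion, with a stated time of 48 h, tested at 10 uM (on this read-out higher numbers stand for a weaker effect at the one concentration tested and lower numbers for a stronger effect), compound 1 `CCCCCCC#Cc1ccc(S(=O)(=O)Nc2cccc(-c3csc(NC(C)=O)n3)c2)cc1` gives 5.8%, the highest of the two numbers shown. Compound 3 `C#Cc1ccc(S(=O)(=O)Nc2cccc(-c3csc(NC(C)=O)n3)c2)cc1` gives 1.2%, and the step of a number 4.6 percentage points lower from compound 1 to compound 3 (within the scatter) stays within the scatter. Compound 2 `CCCCC#Cc1ccc(S(=O)(=O)Nc2cccc(-c3csc(NC(C)=O)n3)c2)cc1` shows only a limit, < 1%. The step of a number at least 4.8 percentage points lower from compound 1 to compound 2 (that floor lies within the scatter) and the step of a number at least 0.2 percentage points higher from compound 2 to compound 3 (that floor lies within the scatter) likewise stay within the scatter. Compound 4 `CCCCCCC#Cc1ccc(S(=O)(=O)Nc2cccc(-c3csc(N)n3)c2)cc1` differs from compound 1 by hydrogen in place of acetyl on a nitrogen on an aromatic ring. For the measured compounds named here, none of the measured steps touches this nitrogen; all concern the chain on the triple-bonded carbon, and none moved the read-out beyond the scatter. Going by the values given here, no measured step therefore bears directly on the change, and in this assay no step beyond the scatter is expected. Compound 4 is accordingly estimated at 5%, between 0% and 15%. The expected step is a number 0.8 percentage points lower from compound 1 to compound 4 (within the scatter).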

Compound 4, a percentage reported as activity, at one concentration (the size of the read-out at that concentration, not a potency): 3.5%
Compound 4: middle estimate off by 1.5 percentage points, on the high side; low and high end bracket the measured number.
By their numbers in this assay, from the lowest: compounds 3, 4 and 1 (each within the scatter of the next). At a limit, below all of these: compound 2.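

Replacing acetyl with hydrogen on a nitrogen on an aromatic ring gives, in this assay, a number 2.3 percentage points lower from compound 1 to compound 4 (within the scatter). This is the first step shown at this nitrogen, and like the steps on the chain, it does not go beyond the scatter. Little room remains for reading any change, as the values of this series lie close to the limit of the assay: the limit of < 1% in this assay, at which 1 of the 4 values shown sits.

On these data alone, whether a methyl, a benzoyl or a sulfonamide on this nitrogen would also stay within the scatter remains open. So does whether amino and acetamido would stay level with butyl or hydrogen in place of hexyl on the triple-bonded carbon.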